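Aryl piperazine variation on the shared core

The source may hold more compounds than are shown below. What is called first, only, known or untested is meant among the compounds shown, and "the series" means these compounds.

The series keeps the core shown in compound 1 `S=c1oc(-c2ccc3c(c2)OCCO3)nn1CN1CCN(c2cccc(Cl)c2)CC1` and varies the aryl group on the ring amine nitrogen. In a functional assay on SW 1116 cells (Homo sapiens) for antiproliferative activity, read by MTT assay, with a stated time of 48 h (a lower number here means a stronger inhibitor, a higher number a weaker inhibitor), compound 1 gives > 50000 nM, which is a limit of the assay and not a number. Compound 2 `Fc1ccc(N2CCN(Cn3nc(-c4ccc5c(c4)OCCO5)oc3=S)CC2)cc1` carries 4-fluorophenyl, and in this assay compound 2 gives > 50000 nM, again a limit. Going by the values given here, compound 3 `COc1ccc(N2CCN(Cn3nc(-c4ccc5c(c4)OCCO5)oc3=S)CC2)cc1` carries 4-methoxyphenyl, and in this assay compound 3 gives 24200 nM, the only readable number in the set. The step of an at least 2.0-fold lower number from compound 1 to compound 3 (0.31 log units; beyond the scatter) and the step of an at least 2.0-fold lower number from compound 2 to compound 3 (0.31 log units; beyond the scatter) both run toward the methoxy compound, while the step that the two limits leave unreadable from compound 1 to compound 2 cannot be read because of the limit of > 50000 nM in this assay, at which 2 of the 3 values shown sit.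

Compound 4 `S=c1oc(-c2ccc3c(c2)OCCO3)nn1CN1CCN(c2ccccc2Cl)CC1` is not yet measured. It differs from compound 3 by 2-chlorophenyl in place of 4-methoxyphenyl on an amine nitrogen in a ring. Among the compounds with values here, this removes the methoxy group tied to the only readable number and brings in 2-chlorophenyl, a chlorine-bearing aryl group as in compound 1, whose value sits at the limit of > 50000 nM in this assay, at which 2 of the 3 values shown sit. Both readable steps, though modest, ran away from the halogenated aryl groups, so a move back to a higher number is expected. The expected step is a 2.5-fold higher number from compound 3 to compound 4 (0.39 log units; beyond the scatter) in this assay. The estimate for compound 4 is 60000 nM, ranging from 20000 nM to 200000 nM, with a real chance that only a limit is reported.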

Compound 4, half-maximal inhibitory concentration: > 50000 nM
Compound 4: a limit, no number (the forecaster's own chance of this, stated with the estimate: 65%); the middle value lies beyond the limit too.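

In this assay the change from 4-methoxyphenyl to 2-chlorophenyl gives an at least 2.0-fold higher number from compound 3 to compound 4 (0.31 log units; beyond the scatter), so a third aryl group without the methoxy now falls short of compound 3. Going by these compounds alone, compound 3 remains the only compound in the set with a readable number, while the 3-chlorophenyl, 4-fluorophenyl and 2-chlorophenyl compounds all end at one limit, which is not a number: the limit of > 50000 nM in this assay, at which 3 of the 4 values shown sit. The steps among compound 1, compound 2 and compound 4 cannot be read, so the data do not order these three aryl groups, and the chlorine-bearing pair, compound 1 and compound 4, cannot be told apart.

Still open, on these data alone, is whether the readable number is tied to the methoxy group itself or would also appear with an ethoxy group, a hydroxyl group or a dimethylamino group on the phenyl ring. With compound 3 as the single readable point, the series also gives no size for any trend on this aryl group, and no sign of whether any group here can bring the number much lower.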